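Bromophenyl Triazole Ester of a Terpenoid Core

The source may hold more compounds than are shown below. What is called first, only, known or untested is meant among the compounds shown, and "the series" means these compounds.

Compound 1 `C/C(=C\CC/C(C)=C/CC[C@@H]1[C@@]2(C)CCC(=O)C(C)(C)[C@H]2CC[C@@]1(C)O)CC/C=C(\C)C(=O)OCc1cn(-c2cccc(Cl)c2)nn1` and compound 2 `C/C(=C\CC/C(C)=C/CC[C@@H]1[C@@]2(C)CCC(=O)C(C)(C)[C@H]2CC[C@@]1(C)O)CC/C=C(\C)C(=O)OCc1cn(-c2cccc(C(F)(F)F)c2)nn1` share a core and differ only by trifluoromethyl in place of chloro on an aromatic carbon. In a functional assay on DU-145 cells (Homo sapiens) for antiproliferative activity, read by MTT assay, with a stated time of 48 h (a higher number here means a weaker inhibitor, a lower number a stronger inhibitor), compound 1 gives 103000 nM. For compound 2 the readout is a limit of the assay, > 150000 nM, so compound 2 stands at the limit of > 150000 nM in this assay, at which 1 of the 2 values shown sits, and carries no number of its own. Among the measured compounds shown here, the single measured step, an at least 1.4-fold higher number from compound 1 to compound 2 (0.16 log units; that floor lies within the scatter), is the only one that bears on the next change. Compound 3 `C/C(=C\CC/C(C)=C/CC[C@@H]1[C@@]2(C)CCC(=O)C(C)(C)[C@H]2CC[C@@]1(C)O)CC/C=C(\C)C(=O)OCc1cn(-c2ccccc2Br)nn1` carries 2-bromophenyl in place of 3-(trifluoromethyl)phenyl on an aromatic nitrogen. Because compound 1 with chloro gives 103000 nM, compound 3 is expected to land near that figure, giving an estimated step of an at least 1.2-fold lower number from compound 2 to compound 3 (0.09 log units; that floor lies within the scatter). Compound 3 is therefore expected to give 120000 nM in this assay, with a range from 50000 nM to 300000 nM.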

Compound 3, half-maximal inhibitory concentration: > 150000 nM
Compound 3 was reported as a limit; the forecaster's own chance of this, stated with the estimate: 45%; at least 1.2-fold (0.09 log units) between middle value and limit.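

In this assay compound 3, with 2-bromophenyl on the aromatic nitrogen, also reads only as a limit of the assay, so this second replacement of 3-chlorophenyl gives no readable value either. Set against 3-chlorophenyl, the change to 2-bromophenyl amounts to an at least 1.4-fold higher number from compound 1 to compound 3 (0.16 log units; that floor lies within the scatter). The step between compound 2 and compound 3 cannot be read, and compound 1 is now the only compound of the three with a number of its own, the other two sitting at one ceiling: the limit of > 150000 nM in this assay, at which 2 of the 3 values shown sit.

On these data alone, it remains open whether compound 1 truly differs from compound 2 and compound 3 by more than the scatter, and whether any group on that nitrogen gives a clearly stronger inhibitor. A phenyl ring bearing an amine or a carboxylic acid, or a benzyl group in place of the phenyl, would bear on this.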